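The source may report more compounds than this note shows. Statements on the series, on what has been measured and on what is new or still open speak of the compounds shown alone.

Measured compounds in a functional assay on HeLa cells (Homo sapiens) for cytotoxicity, read by MTT assay, with a stated time of 48 h; on this read-out higher numbers stand for weaker inhibition and lower numbers for stronger inhibition:

compound 1 `O=c1ccoc2cc(OCc3cn(Cc4ccc(F)cc4)nn3)ccc12`: 12000 nM
compound 2 `O=c1ccoc2cc(OCc3cn(Cc4cccc(Cl)c4)nn3)ccc12`: > 100000 nM, a limit of the assay and not a number

Compound 2 sits at the top of the two values shown; for it this assay gives only a limit, so where it stands within the weak end is not known. Among the compounds with values here, the one step measured so far is an at least 8.3-fold higher number from compound 1 to compound 2 (0.92 log units; beyond the scatter), a change of the group on the saturated chain carbon bound to the aromatic nitrogen, and it runs toward weaker inhibition, with compound 2 at the limit of > 100000 nM in this assay, at which 1 of the 2 values shown sits.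

Compound 3 is `N#Cc1cccc(Cn2cc(COc3ccc4c(=O)ccoc4c3)nn2)c1`. It differs from compound 2 by cyano in place of chloro on an aromatic carbon. Within the data shown here, no measured step exchanges one substituent for another on this ring while the position is held, so the step from compound 1 to compound 2 bears on it only loosely, as a sign that this ring tolerates change poorly. Compound 3 is therefore expected near where compound 2 stands, with the step of a number no higher from compound 2 to compound 3 (the limit leaves the size open) not beyond the scatter in either direction. Compound 3 is estimated at 100000 nM, with a range of 25000 nM to 300000 nM.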

Compound 3, half-maximal inhibitory concentration: > 100000 nM
Compound 3: only a limit was reported; the forecaster's own chance of this, stated with the estimate: 55%; the middle value lies on the limit itself.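

In this assay compound 3 gives > 100000 nM, which is a limit of the assay and not a number. Replacing 4-fluorophenyl with 3-cyanophenyl gives an at least 8.3-fold higher number from compound 1 to compound 3 (0.92 log units; beyond the scatter), toward weaker inhibition, so the shift seen with 3-chlorophenyl is no longer a single case but appears with a second group at the same place on the ring. The step between compound 2 and compound 3 cannot be read, so chloro and cyano are not ordered here, and the new information is only that a second group now sits at the weak end of the series: the limit of > 100000 nM in this assay, at which 2 of the 3 values shown sit.

The compounds shown contain no pair that holds one group and moves it around this ring, so the change of place and the change of group cannot be separated as sources of the loss seen from compound 1. Also open, as far as these compounds go, is whether an amine or a carboxylic acid at this place on the ring would bring the read-out back from the limit to a measurable number.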